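Shifting One Fluorine Across Two Related Cores

This account rests on a few compounds, and the source may have more. Where it says the series, first, only, none or still open, it means among the compounds named here.

Compound 1 `O=c1[nH]cc(S(=O)(=O)Nc2ccccc2-c2cn(-c3ccccc3F)nn2)c(=O)[nH]1` and compound 3 `O=c1[nH]cc(S(=O)(=O)Nc2cccc(-c3cn(-c4ccccc4F)nn3)c2)c(=O)[nH]1` contain the same atoms joined differently, and the difference between the two cores is not broken down here. In a functional assay on SGC-7901 cells (Homo sapiens) for antiproliferative activity, read by MTT assay, with a stated time of 24 h (a higher number here means a weaker inhibitor, a lower number a stronger inhibitor), compound 1 gives 10800 nM, and compound 3 gives 16000 nM, the two sitting within the usual scatter of each other. Compound 2 `O=c1[nH]cc(S(=O)(=O)Nc2ccccc2-c2cn(-c3cccc(F)c3)nn2)c(=O)[nH]1` carries 3-fluorophenyl in place of 2-fluorophenyl on an aromatic nitrogen. In this assay compound 2 reaches only > 20000 nM, which is a limit of the measurement rather than a number. That change gives an at least 1.8-fold higher number from compound 1 to compound 2 (0.26 log units; that floor lies within the scatter). Compound 4 `O=c1[nH]cc(S(=O)(=O)Nc2cccc(-c3cn(-c4cccc(F)c4)nn3)c2)c(=O)[nH]1` is not yet measured and carries the same change on the core of compound 3, (3-fluorophenyl in place of 2-fluorophenyl on an aromatic nitrogen). Because the earlier change produced an at least 1.8-fold higher number from compound 1 to compound 2 (0.26 log units; that floor lies within the scatter), a step in the same direction is expected, and compound 4 is estimated at a 1.8-fold higher number from compound 3 to compound 4 (0.24 log units; within the scatter). Compound 4 is therefore expected to give about 28000 nM, quite possibly reported only as the limit of > 20000 nM in this assay, at which 1 of the 3 values shown sits, with a plausible range from 14000 nM to 60000 nM.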

Compound 4, half-maximal inhibitory concentration: > 20000 nM
Compound 4: only a limit was reported; the forecaster's own chance of this, stated with the estimate: 65%; the middle value lies beyond the limit too.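

In this assay, 3-fluorophenyl in place of 2-fluorophenyl gives an at least 1.2-fold higher number from compound 3 to compound 4 (0.09 log units; that floor lies within the scatter), a step that rests on a limit rather than a number. Both steps have floors within the usual scatter, so they fit the change carrying over from one core to the other without showing that it does: the same change on two cores in this assay, an at least 1.8-fold higher number (0.26 log units; that floor lies within the scatter) from compound 1 to compound 2 and an at least 1.2-fold higher number (0.09 log units; that floor lies within the scatter) from compound 3 to compound 4; the limit leaves it open whether they differ. Nor can the size of the step on either core be read, since compound 2 and compound 4 both stop at the same limit: the limit of > 20000 nM in this assay, at which 2 of the 4 values shown sit.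

As far as these compounds go, the real values of compound 2 and compound 4 stay open. So does whether a chlorine or a methoxy group in place of the fluorine would give a value that can be compared on both cores.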